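One More Methoxy on a Weakly Cytotoxic Compound

A few compounds are considered here, and "the series" means these few. Any claim that something is new, unique, unknown or untested is made for them only; others in the source may bear on it.

In a functional assay on PC-3 cells (Homo sapiens) for cytotoxicity, read by MTT assay, with a stated time of 48 h (on this read-out higher numbers stand for weaker inhibition and lower numbers for stronger inhibition), compound 1 `COc1ccc(-c2c(-c3cc(OC)c(OC)c(OC)c3)noc2N)cc1OC` gives 21100 nM as its value. Compound 2 `COc1ccc(-c2c(-c3cc(OC)c(OC)c(OC)c3)noc2NC(C)=O)cc1` stands at > 50000 nM and this is only a limit of the assay. Compound 3 `COc1ccc(-c2c(-c3cc(OC)c(OC)c(OC)c3)noc2NC(C)=O)cc1OC` differs from compound 2 by methoxy in place of hydrogen on an aromatic carbon, turning 4-methoxyphenyl into 3,4-dimethoxyphenyl methoxy in place of hydrogen on an aromatic carbon on the shared core. Among the measured compounds shown here, no measured step isolates this change. Compound 1 already carries 3,4-dimethoxyphenyl and gives only 21100 nM in this assay so weak inhibition should persist. In this assay the expected step of an at least 1.2-fold lower number from compound 2 to compound 3 (0.09 log units; that floor lies within the scatter) is small and runs toward stronger inhibition. The estimated value for compound 3 is 40000 nM with 15000 nM to 100000 nM as its range.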

Compound 3, half-maximal inhibitory concentration: > 50000 nM
Compound 3 gave a limit, no number; the forecaster's own chance of this, stated with the estimate: 50%; middle value at least 1.2-fold (0.09 log units) away from the limit.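

In this assay, compound 3 is also a limit of the assay, so the step for methoxy in place of hydrogen on an aromatic carbon cannot be read: the limit of > 50000 nM in this assay, at which 2 of the 3 values shown sit. The one readable new result concerns the other change: with 3,4-dimethoxyphenyl shared, acetyl in place of hydrogen on a nitrogen on an aromatic ring gives an at least 2.3-fold higher number from compound 1 to compound 3 (0.37 log units; beyond the scatter). From the compounds shown here alone, whether the added methoxy has any effect therefore remains open. Also open, going by these compounds, is how a longer chain or a carboxylic acid in place of the acetyl would read in this assay.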